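This account rests on a few compounds, and the source may have more. Where it says the series, first, only, none or still open, it means among the compounds named here.

Working notes on the series. In an assay on membranes from CHO cells for displacement of a labelled ligand from adenosine receptor A1 (Homo sapiens), read by scintillation counting, with a stated time of 60 min, tested at 1 uM (on this read-out higher numbers stand for more inhibition at the one concentration tested (going by the name of the read-out) and lower numbers for less inhibition), compound 1 `CCCOC(=O)C1=C(C)NC(=O)NC1c1cccs1` gives 43%. Compound 2 `CCCOC(=O)C1=C(C)NC(=O)NC1c1ccsc1` gives 44% in this assay, so the change thiophen-3-yl in place of thiophen-2-yl on a saturated ring carbon produced a step of a number 1 percentage points higher from compound 1 to compound 2 (within the scatter). Compound 3 `COC(=O)C1=C(C)N(C)C(=O)NC1c1cccs1` gives 30% in this assay and stands lowest of the three measured; the difference between its core and the core of compound 1 is not broken down here. Compound 4 `COC(=O)C1=C(C)N(C)C(=O)NC1c1ccsc1` carries the change (thiophen-3-yl in place of thiophen-2-yl on a saturated ring carbon). This is the same kind of change as before, though the place is now next to the ring atom that bears a methoxycarbonyl group rather than a propoxycarbonyl group, and also three ring bonds from the ring atom that bears a methyl group. The expectation rests on compound 1 and compound 2, whose step was a number 1 percentage points higher from compound 1 to compound 2 (within the scatter). The expected step is a number 1 percentage points higher from compound 3 to compound 4 (within the scatter). Compound 4 is therefore estimated to give 31%, between 18% and 44%.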

Compound 4, a percentage reported as inhibition, at one concentration (the size of the read-out at that concentration, not a potency): 24%
For compound 4 the middle estimate is 7 percentage points above the measured one; the measured number falls inside the stated range.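

The new step is a number 6 percentage points lower from compound 3 to compound 4 (within the scatter), so thiophen-3-yl in place of thiophen-2-yl stays within the scatter on this core too. Set side by side, the two steps give no sign that the outcome of this change depends on the core in this assay: the same change on two cores in this assay, a number 1 percentage points higher (within the scatter) from compound 1 to compound 2 and a number 6 percentage points lower (within the scatter) from compound 3 to compound 4, 7 percentage points apart, within the scatter of two such steps. Two pairs read at one concentration do not show that the steps are identical, that the change would stay this small on any other core, or how potency compares.

Open, going by these compounds, is how a phenyl or furan-2-yl group would read on the same saturated ring carbon. Also open, on these data alone, is how a carboxylic acid or an amide would read in place of the methoxycarbonyl group.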